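Cyano for ethoxy at the cytotoxicity limit

The source may report more compounds than this note shows. Statements on the series, on what has been measured and on what is new or still open speak of the compounds shown alone.

Two members of the series have been read in an ADME assay on HEK293 cells (Homo sapiens) for cytotoxicity, with a stated time of 72 h (on this read-out higher numbers stand for an effect only at larger amounts of compound and lower numbers for an effect already at smaller amounts), so far. Compound 1 `C=C[C@@](C)(/C=C/c1ccc(O)cc1)CC/C=C/C#N` gives > 36600 nM as a limit of the assay, not a number. Compound 2 `CCOc1ccc(/C=C/[C@@](C)(/C=C/c2ccc(O)cc2)CCC=C(C)C)cc1` gives > 36600 nM as a limit as well, so it stands without a numerical value. The record for the series is the limit of > 36600 nM in this assay, at which 2 of the 2 values shown sit, and nothing more.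

Compound 3 `CC(C)=CCC[C@](C)(/C=C/c1ccc(O)cc1)/C=C/c1ccc(C#N)cc1` carries cyano in place of ethoxy on an aromatic carbon, para to a large group, and the count of that change reads cyano in place of ethoxy on an aromatic carbon for the 4-ethoxyphenyl to 4-cyanophenyl difference.

Going by the values given here, no step between measured compounds is available to size this change. In this assay no step beyond the scatter is expected, and no direction is favoured. The estimated a number no higher from compound 2 to compound 3 (the limit leaves the size open) is therefore expected to stay within the usual scatter of repeated measurements. For compound 3 the expected value is 36600 nM within an estimated range of 15000 nM to 70000 nM and a report as a limit again is the likeliest outcome.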

Compound 3, half-maximal effective concentration: > 36600 nM
Compound 3: only a limit was reported; the forecaster's own chance of this, stated with the estimate: 80%; the middle value sits exactly at the limit.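

Compound 2 and compound 3 are both reported only as limits, not numbers, in this assay, so no step can be read for cyano in place of ethoxy. The compounds shown leave open at what concentration any of them would reach a half-maximal effect, and whether that exchange shifts it at all; the record stands at: the limit of > 36600 nM in this assay, at which 3 of the 3 values shown sit.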